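Ethyl in Place of Hydrogen: Expected Acid Dissociation of Compound 4

This account rests on a few compounds, and the source may have more. Where it says the series, first, only, none or still open, it means among the compounds named here.

Measured so far:
compound 1 `C#CC(C)OC[n+]1ccn(C)c1/C=N/O` gives 7.96
compound 2 `C#CC(CCC)OC[n+]1ccn(C)c1/C=N/O` gives 8.02
compound 3 `C#CCC(C)OC[n+]1ccn(C)c1/C=N/O` gives 8.03

All three were measured in a physicochemical assay for acid dissociation. Compound 4 `C#CCC(CCC)OC[n+]1ccn(C)c1/C=N/O` has not been measured yet. It differs from compound 3 by ethyl in place of hydrogen on a saturated chain carbon, two bonds along the chain from an oxygen on a saturated carbon. The same kind of change separates compound 1 from compound 2, where the difference is ethyl in place of hydrogen on a saturated chain carbon, two bonds along the chain from an oxygen on a saturated carbon and a triple-bonded carbon; around that place the chain is also two bonds from a triple-bonded carbon, which is not stated for the place in compound 3. The two cores themselves differ as given by propargyl in place of ethynyl on a saturated chain carbon bound to an oxygen on a saturated carbon and a saturated chain carbon. The earlier change produced a number 0.06 log units higher from compound 1 to compound 2 (within the scatter). A step of similar size, a number 0.06 log units higher from compound 3 to compound 4 (within the scatter), is expected from the ethyl for hydrogen change here. Because a number 0.06 log units higher from compound 1 to compound 2 (within the scatter) stayed within the scatter, compound 4 is expected to give 8.09, with a range from 7.85 to 8.35.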

Compound 4, acid dissociation constant: 7.92
The estimate for compound 4 lay 0.17 log units above the measured number; the range from low to high includes it.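

In this assay, ethyl in place of hydrogen gives a number 0.06 log units higher from compound 1 to compound 2 (within the scatter) on one core and a number 0.11 log units lower from compound 3 to compound 4 (within the scatter) on the other, and with ethyl present on both, propargyl in place of ethynyl gives a number 0.10 log units lower from compound 2 to compound 4 (within the scatter). This shows that on both cores the ethyl change stays inside the usual scatter, but it does not show that the change has a real effect of the same size or direction on each, since steps this small cannot be told apart. Nothing available here bears on why the numbers fall as they do.

As far as these compounds go, it remains open whether a longer chain in place of ethyl would give a step beyond the scatter on either core. The same question stands for an amine or a carboxylic acid at this place on the saturated chain carbon.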